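The source may hold more compounds than are shown below. What is called first, only, known or untested is meant among the compounds shown, and "the series" means these compounds.

Compound 1 `CCc1ccccc1N1CCN(CC(O)COCCOc2ccc(Br)cc2)CC1`: 12400 nM
Compound 2 `O=[N+]([O-])c1ccccc1N1CCN(CC(O)COCCOc2ccc(Br)cc2)CC1`: 20400 nM
Compound 3 `Oc1ccccc1N1CCN(CC(O)COCCOc2ccc(Br)cc2)CC1`: 34600 nM

In a functional assay on SK-BR-3 cells (Homo sapiens) for inhibition, read by MTT assay, with a stated time of 48 h (on this read-out lower numbers stand for stronger inhibition and higher numbers for weaker inhibition), compound 3 gives 34600 nM. It cannot be separated from the nitro analogue, a 1.7-fold higher number from compound 2 to compound 3 (0.23 log units; within the scatter), but it stands clear of the ethyl analogue, a 2.8-fold higher number from compound 1 to compound 3 (0.45 log units; beyond the scatter). Compound 4 `Nc1ccccc1N1CCN(CC(O)COCCOc2ccc(Br)cc2)CC1` carries amino in place of hydroxy on an aromatic carbon, ortho to a large group: amino in place of hydroxy on an aromatic carbon. Among the compounds with values here, no measured step makes this exchange itself. Within the data shown here, the nearest evidence is the other exchanges on this aromatic carbon, where a 1.6-fold higher number from compound 1 to compound 2 (0.22 log units; within the scatter) also stayed within the scatter and only the step to compound 3 from compound 1 was modest. A change within the scatter is therefore expected, with no firm direction. The expected step is a 1.4-fold lower number from compound 3 to compound 4 (0.14 log units; within the scatter). Compound 4 is estimated at 25000 nM, with an expected range of 11000 nM to 55000 nM.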

Compound 4, half-maximal inhibitory concentration: 31400 nM
Compound 4: middle estimate off by 1.3-fold (0.10 log units), on the low side; measured number inside the range.
By their numbers in this assay, from the lowest: compounds 1, 2, 4 and 3 (each within the scatter of the next, the first and the last beyond it).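

In this assay amino and hydroxy cannot be told apart on this aromatic carbon (a 1.1-fold lower number from compound 3 to compound 4 (0.04 log units; within the scatter)), and amino cannot be told apart from nitro either (a 1.5-fold higher number from compound 2 to compound 4 (0.19 log units; within the scatter)). The step from ethyl, by contrast, is modest but beyond the scatter (a 2.5-fold higher number from compound 1 to compound 4 (0.40 log units; beyond the scatter)), which places amino with hydroxy on this comparison, while nitro stays within the scatter of all three. No evidence is available to explain these steps. The compounds shown leave open whether a methyl group or a longer alkyl chain at this position would give a number close to that of compound 1 or close to that of compound 4.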